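Two Compounds Measured in Mice, a Third Awaited

A few compounds are considered here, and "the series" means these few. Any claim that something is new, unique, unknown or untested is made for them only; others in the source may bear on it.

Compound 1 `COc1cc(OC)c(OC)cc1/C=C/COC(=O)/C=C/c1cc(OC)c(OC)c(OC)c1` and compound 2 `COc1cc(OC)c(OC)cc1/C=C/COC(=O)/C=C/c1cccc(Br)c1` were both tested in a functional assay on the whole organism (strain Kunming) with Mus musculus as the target, with a stated time of 0.5 h, at a dose of 300 mg/kg by the intraperitoneal route; on this read-out lower numbers stand for a stronger effect and higher numbers for a weaker effect at the one dose given. In this assay compound 1 gives 50%, and compound 2 gives 50%. Compound 2 therefore stands level with compound 1, the two values lying within the scatter of one another. Compound 3 `COc1cc(OC)c(OC)cc1/C=C/COC(=O)/C=C/c1ccccc1Cl` differs from compound 2 in a single place: 2-chlorophenyl in place of 3-bromophenyl on a double-bonded chain carbon bound to a double-bonded chain carbon. Among the measured compounds shown here, no step between measured compounds is available to guide this change. The step of no change at the digits printed from compound 2 to compound 3 (within the scatter) is expected to stay within the scatter, in neither direction. Compound 3 is accordingly estimated at 50%, with a range from 30% to 70%.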

Compound 3, a percentage reported as activity, at one dose (the size of the read-out at that dose, not a potency): 50%
The estimate for compound 3 equals the measured number at the digits printed; measured number inside the range.
By their numbers in this assay, from the lowest: compounds 1, 2 and 3 (each within the scatter of the next).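

In this assay, putting 2-chlorophenyl in place of 3-bromophenyl on a double-bonded chain carbon bound to a double-bonded chain carbon gives no change at the digits printed from compound 2 to compound 3 (within the scatter). The earlier compounds shown here offered no step at this place, and this one shows that this exchange of one halogen-bearing phenyl group for another leaves the read-out unchanged at this single dose. Nothing available explains this result. Going by these compounds, what remains open is whether the read-out would also hold with an unsubstituted phenyl group, or with an amine or a carboxylic acid on the phenyl ring in place of the halogen.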